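Lengthening the Alkyl Chain on the Aromatic Nitrogen

This account rests on a few compounds, and the source may have more. Where it says the series, first, only, none or still open, it means among the compounds named here.

Three compounds have been measured in an assay on Prostate gland for inhibition of steroid 5-alpha-reductase (Rattus norvegicus); on this read-out higher numbers stand for weaker inhibition and lower numbers for stronger inhibition:
compound 1, `CCCCC(CCCC)n1ccc2cc(/C(C)=C/C(=O)Nc3ccccc3OCCCC(=O)O)ccc21`, gives 21 nM;
compound 2, `C/C(=C\C(=O)Nc1ccccc1OCCCC(=O)O)c1ccc2c(ccn2Cc2cccc(C)c2)c1`, gives 250 nM;
compound 3, `CCC(c1ccccc1)n1ccc2cc(/C(C)=C/C(=O)Nc3ccccc3OCCCC(=O)O)ccc21`, gives 19 nM.

Compound 3 gives the lowest number of the three, yet the step of a 1.1-fold lower number from compound 1 to compound 3 (0.04 log units; within the scatter) lies within the scatter, so compounds 1 and 3 cannot be told apart; only compound 2 stands clearly apart, as a 13-fold lower number from compound 2 to compound 3 (1.12 log units; beyond the scatter) shows. The unmeasured compound 4, `CCCC(c1ccccc1)n1ccc2cc(/C(C)=C/C(=O)Nc3ccccc3OCCCC(=O)O)ccc21`, differs from compound 3 by methyl in place of hydrogen on a saturated chain carbon, three bonds along the chain from an aromatic carbon and an aromatic nitrogen; the change turns 1-phenylpropyl into 1-phenylbutyl. For the measured compounds named here, two measured steps bear on the substituent on this nitrogen. The swap of the whole branched group, a 1.1-fold lower number from compound 1 to compound 3 (0.04 log units; within the scatter), left the number where it was, while replacing a branched group by a benzyl, a 12-fold higher number from compound 1 to compound 2 (1.08 log units; beyond the scatter), raised it sharply. Adding one carbon to a branched group that already carries a phenyl is a far smaller change than either, so in this assay no step beyond the scatter is expected, a 1.1-fold lower number from compound 3 to compound 4 (0.02 log units; within the scatter). Compound 4 is estimated at 18 nM, with a range from 8 nM to 45 nM.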

Compound 4, half-maximal inhibitory concentration: 9.1 nM
Estimate against measurement, compound 4: 2.0-fold (0.30 log units) above, within the range that was stated.
By their numbers in this assay, from the lowest: compound 4; then compounds 3 and 1 (each within the scatter of the next); then compound 2.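

In this assay, turning 1-phenylpropyl into 1-phenylbutyl gives a 2.1-fold lower number from compound 3 to compound 4 (0.32 log units; beyond the scatter) and so shows that this saturated chain carbon still responds to a single added methyl, which the swaps of whole groups could not show. The change also gives 1-phenylbutyl a measurable edge over 1-butylpentyl (a 2.3-fold lower number from compound 1 to compound 4 (0.36 log units; beyond the scatter)), whereas 1-phenylpropyl could not be told apart from that group, and it widens the gap to 3-methylbenzyl (a 27-fold lower number from compound 2 to compound 4 (1.44 log units; beyond the scatter)). No measurement on hand explains why the added methyl lowers the number.

From the compounds shown here alone, whether a longer chain such as 1-phenylpentyl would lower the number further or raise it again remains open. So does the effect on the number of an amine or a hydroxyl at the end of this chain.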